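From 3-hydroxybenzyl to 3,4-dihydroxyphenyl at the ring oxygen

The compounds below may be only part of what the source reports. "The series", "measured", "known", "first", "only" and "open" are said of these compounds alone.

In a functional assay on HeLa cells (Homo sapiens) for inhibition, read by CCK-8 assay, with a stated time of 48 h (a higher number here means a weaker inhibitor, a lower number a stronger inhibitor), compound 1 `O=S(=O)(NCCNC(=S)Nc1cccc(Cl)c1)c1ccc(-c2ccccc2OCc2cccc(O)c2)s1` gives 10700 nM. Compound 2 `O=C(NCCNS(=O)(=O)c1ccc(-c2ccccc2OCc2cccc(O)c2)s1)Nc1cc(Cl)cc(Cl)c1` gives > 50000 nM, which is a limit of the assay and not a number. Its position is therefore known only as the limit of > 50000 nM in this assay, at which 1 of the 2 values shown sits.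

Compound 3 `O=C(NCCNS(=O)(=O)c1ccc(-c2ccccc2Oc2ccc(O)c(O)c2)s1)Nc1cc(Cl)cc(Cl)c1` keeps the group on the amine nitrogen of compound 2 and changes the other end of the molecule: 3,4-dihydroxyphenyl in place of 3-hydroxybenzyl on an oxygen on an aromatic ring. In words, 3,4-dihydroxyphenyl stands in place of 3-hydroxybenzyl on an oxygen on an aromatic ring.

Among the measured compounds shown here, the only measured step is an at least 4.6-fold higher number from compound 1 to compound 2 (0.66 log units; beyond the scatter). For the measured compounds named here, it lies at the amine nitrogen, so it bears on this change only indirectly, and no measured step covers the new position. It does show that compound 1, at 10700 nM, reaches a measurable value with the 3-hydroxybenzyl group in place. A modest move to a lower number in this assay is expected, though another limit remains quite possible. The expected change is an at least 1.6-fold lower number from compound 2 to compound 3 (0.22 log units; that floor lies within the scatter). For compound 3 the estimate is 30000 nM, with an expected range of 9000 nM to 50000 nM.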

Compound 3, half-maximal inhibitory concentration: > 20000 nM
Compound 3: only a limit was reported; the forecaster's own chance of this, stated with the estimate: 45%; the middle value lies beyond the limit too.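

In this assay compound 3 gives > 20000 nM, which is a limit of the assay and not a number. Compound 2 gives > 50000 nM, also a limit, so the step from compound 2 to compound 3 cannot be read. Still open, as far as these compounds go, is whether 3,4-dihydroxyphenyl in place of 3-hydroxybenzyl on an oxygen on an aromatic ring changes the number at all.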